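Adding a second chlorine: notes on compounds 1 to 3

The source may report more compounds than this note shows. Statements on the series, on what has been measured and on what is new or still open speak of the compounds shown alone.

Compound 1 `O=C1NC(=S)/C(=C/c2ccc(Cl)cc2)S1`: 28.6%
Compound 2 `O=C1NC(=S)/C(=C/c2ccccc2Cl)S1`: 19.9%

In a functional assay on NCI-H292 cells (Homo sapiens) for cytotoxicity, read by MTT assay, with a stated time of 72 h, tested at 2.5 ug/mL (on this read-out higher numbers stand for more inhibition of growth at the one concentration tested and lower numbers for less inhibition of growth), compound 2 gives the lower of the two numbers shown, but its gap to compound 1 lies within the scatter, so no order between them is claimed. Compound 3 `O=C1NC(=S)/C(=C/c2ccc(Cl)cc2Cl)S1` differs from compound 2 by chloro in place of hydrogen on an aromatic carbon. For the measured compounds named here, no measured pair shows this change, so only a modest upward shift, not clearly beyond the scatter, is expected. For compound 3 the estimated growth inhibition is 26%, with a range from 12% to 42%. This estimate means an expected step of a number 6.1 percentage points higher from compound 2 to compound 3 (within the scatter).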

Compound 3, percent growth inhibition at one concentration: 14.7%
Compound 3: middle estimate off by 11.3 percentage points, on the high side; the measured number falls inside the stated range.
By their numbers in this assay, from the lowest: compounds 3, 2 and 1 (each within the scatter of the next, the first and the last beyond it).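

In this assay, chloro in place of hydrogen on an aromatic carbon, meta to a chloro group and para to a group of 8 heavy atoms, gives a number 5.2 percentage points lower from compound 2 to compound 3 (within the scatter), so this position shows no readable change on its own. For the compounds shown here, the same change read from the other side gives a number 13.9 percentage points lower from compound 1 to compound 3 (beyond the scatter), the only step beyond the scatter, and it points downward rather than upward. No measurement bearing on the reason for this result is at hand.

Still open, as far as these compounds go, is how a methoxy group, an amine or a carboxylic acid at this position would compare with chloro. Also open, from the compounds shown here alone, is whether these steps hold at other concentrations.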